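The compounds below may be only part of what the source reports. "The series", "measured", "known", "first", "only" and "open" are said of these compounds alone.

Measured compounds in a functional assay on PC-3 cells (Homo sapiens) for antiproliferative activity, read by MTT assay, with a stated time of 12 h; a lower number here means a stronger inhibitor, a higher number a weaker inhibitor:

Compound 1 `COc1cc(OC)c2c(=O)cc(/C=C/c3ccc([N+](=O)[O-])cc3)oc2c1` gives > 40000 nM, which is a limit of the assay.
Compound 2 `COc1cc(OC)c2c(=O)cc(/C=C/c3ccncc3)oc2c1` gives > 40000 nM, which is a limit of the assay.
Compound 3 `COc1cc(OC)c2c(=O)cc(/C=C/c3ccc(C(F)(F)F)cc3)oc2c1` gives > 40000 nM, which is a limit of the assay.

Compound 3 therefore stands at the ceiling of what this assay reports: its value is a limit, not a number, and the same holds for the two other compounds shown, so it cannot be placed as stronger or weaker than either of them. Going by the values given here, the one step that touches compound 3 directly, a step that the two limits leave unreadable from compound 1 to compound 3, is unreadable, since both ends are limits; this is the situation described by the limit of > 40000 nM in this assay, at which 3 of the 3 values shown sit.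

Compound 4 `COc1ccc(/C=C/c2cc(=O)c3c(OC)cc(OC)cc3o2)cc1` differs from compound 3 in one place: methoxy in place of trifluoromethyl on an aromatic carbon. Among the compounds with values here, no measured step with a readable size bears on this change. All that can be said is that every compound shown so far sits at the limit, and nothing in the data points to a methoxy group behaving differently. The step from compound 3 to compound 4 is therefore expected to be a number no higher from compound 3 to compound 4 (the limit leaves the size open), with no direction that the data can support. Compound 4 is estimated at 40000 nM, within 8000 nM to 80000 nM.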

Compound 4, half-maximal inhibitory concentration: > 40000 nM
Compound 4: no number, only a limit (the forecaster's own chance of this, stated with the estimate: 70%); the middle value sits exactly at the limit.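

No new step can be read, since the steps to compound 4 from compound 1, compound 2 and compound 3 all end at a limit, not a number: the limit of > 40000 nM in this assay, at which 4 of the 4 values shown sit.

The compounds shown leave open how they rank in this assay, and whether changing the group on the aromatic carbon alters activity at all.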